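This account rests on a few compounds, and the source may have more. Where it says the series, first, only, none or still open, it means among the compounds named here.

Three compounds have been measured in a functional assay on MCF7 cells (Homo sapiens) for antiproliferative activity, read by CCK-8 assay, with a stated time of 72 h; on this read-out higher numbers stand for weaker inhibition of growth and lower numbers for stronger inhibition of growth:

compound 1, `CC[C@@H]1C(=O)N(C)c2cnc(Nc3ccc(S(=O)(=O)NCCO)cc3)nc2N1C1CCCC1`: 344 nM
compound 2, `CCC1C(=O)N(C)c2cnc(-n3ccc4cc(C(=O)NC)ccc43)nc2N1c1ccn(C)n1`: 35400 nM
compound 3, `CCCCNS(=O)(=O)c1ccc(Nc2ncc3c(n2)N(c2ccn(C)n2)C(CC)C(=O)N3C)cc1`: 5780 nM

Among these three, compound 1 gives the lowest number, and its gaps to both compound 3 and compound 2 lie beyond the usual scatter, so compound 1 is the strongest growth inhibitor of the set in this assay. Compound 4, `CC[C@@H]1C(=O)N(C)c2cnc(Nc3ccc(S(=O)(=O)Nc4ccccc4)cc3)nc2N1C1CCCC1`, has not yet been measured. It differs from compound 1 in one place: phenyl in place of 2-hydroxyethyl on a sulfonamide nitrogen. The 2-hydroxyethyl group on the sulfonamide nitrogen is removed and a phenyl takes its place, so the (2-hydroxyethyl)sulfamoyl becomes phenylsulfamoyl, while the rest of the molecule, including the cyclopentyl on the shared core, is unchanged.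

Among the compounds with values here, no measured pair shows this exact change, so there is no direct guide to its size or direction. Compound 3 carries a butylsulfamoyl and a different group on the core, so its value cannot be read as a step for the sulfonamide alone. The expected step from compound 1 to compound 4 in this assay is a 1.6-fold higher number from compound 1 to compound 4 (0.20 log units; within the scatter), a modest weakening, if any, that may fall within the scatter. Compound 4 is therefore estimated at 550 nM, expected to lie between 150 nM and 2500 nM.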

Compound 4, concentration for 50% growth inhibition: 5430 nM
Compound 4: the middle estimate sits 9.9-fold (0.99 log units) below what was measured, outside the stated range (above it).
By their numbers in this assay, from the lowest: compound 1; then compounds 4 and 3 (each within the scatter of the next); then compound 2.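

The sulfonamide nitrogen of compound 1 is not a place where groups can be swapped without consequence: in this assay, phenyl in place of 2-hydroxyethyl gives a 16-fold higher number from compound 1 to compound 4 (1.20 log units; beyond the scatter) and marks a large step. Within the data shown here, this is the first comparison here that changes this position alone, with the cyclopentyl and the rest of the molecule held fixed. The change replaces a ringless chain bearing one hydrogen-bond donor and one acceptor with a six-membered aromatic ring bearing neither, and no measurement here explains the weaker growth inhibition.

The compounds shown leave open whether the step follows from losing the hydroxyl or from gaining the ring. A plain ethyl chain, a 2-methoxyethyl chain or a benzyl group on the same sulfonamide nitrogen, with the cyclopentyl kept, would help separate those two parts of the change.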